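The source may report more compounds than this note shows. Statements on the series, on what has been measured and on what is new or still open speak of the compounds shown alone.

Series notes. In a functional assay on MV4-11 cells (Homo sapiens) for antiproliferative activity, read by CCK-8 assay, with a stated time of 72 h (a lower number here means a stronger inhibitor, a higher number a weaker inhibitor), compound 1 `Cn1cc(-c2ccccc2Oc2ccccc2)c2cc(C(=O)NCCCC(=O)NO)[nH]c2c1=O` gives 380 nM, compound 2 `CC(C)Oc1ccc(C(C)(C)O)cc1-c1cn(C)c(=O)c2[nH]c(C(=O)NCc3ccc(C(=O)NO)cc3)cc12` gives 350 nM, and compound 3 `CC(C)Oc1ccccc1-c1cn(C)c(=O)c2[nH]c(C(=O)NCc3ccc(C(=O)Nc4ccccc4N)cc3)cc12` gives 130 nM. Compound 3 stands lowest of the three numbers; its gaps to compound 2 and to compound 1 both lie beyond the scatter, so it is the strongest inhibitor of the measured set. Compound 4 `COc1ccc(C(C)(C)O)cc1-c1cn(C)c(=O)c2[nH]c(C(=O)NCc3ccc(C(=O)Nc4ccccc4N)cc3)cc12` is not yet measured. It differs from compound 3 in one place: 5-(1-hydroxy-1-methylethyl)-2-methoxyphenyl in place of 2-isopropoxyphenyl on an aromatic carbon. Among the compounds with values here, no pair of measured compounds differs in a single place, so no step of this kind has been seen directly. With the rest of compound 3 kept, a step in this assay within the scatter is expected, direction open. Compound 4 is estimated at 110 nM, range 40 nM to 300 nM. The expected step is a 1.2-fold lower number from compound 3 to compound 4 (0.07 log units; within the scatter).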

Compound 4, half-maximal inhibitory concentration: 420 nM
Beside the measured number, compound 4's estimate is 3.8-fold (0.58 log units) below it; measured number above the stated range.
By their numbers in this assay, from the lowest: compound 3; then compounds 2, 1 and 4 (each within the scatter of the next).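

In this assay, 5-(1-hydroxy-1-methylethyl)-2-methoxyphenyl in place of 2-isopropoxyphenyl on this aromatic carbon gives a 3.2-fold higher number from compound 3 to compound 4 (0.51 log units; beyond the scatter). Within the data shown here, this is the only single-place step so far, and it shows that the number responds to the group at this position. No measurement at hand explains the step.

Open, as far as these compounds go, is which part of the change carries it: methoxy in place of isopropoxy, or the added 1-hydroxy-1-methylethyl group. From the compounds shown here alone, how a plain 2-methoxyphenyl, or an amine or carboxylic acid in place of that hydroxy-bearing group, would read also remains open.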